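Chloropropylureas with sulfonate and sulfonamide linkers

The source may report more compounds than this note shows. Statements on the series, on what has been measured and on what is new or still open speak of the compounds shown alone.

Measured values in a functional assay on M21 cells (Homo sapiens) for cytotoxicity, read by sulforhodamine B assay, with a stated time of 48 h; a lower number here means a stronger inhibitor, a higher number a weaker inhibitor:
compound 1 `CCc1ccccc1OS(=O)(=O)c1ccc(NC(=O)NCCCCl)cc1`: 15000 nM
compound 2 `CCCc1ccccc1OS(=O)(=O)c1ccc(NC(=O)NCCCCl)cc1`: 13000 nM
compound 3 `CCc1ccccc1NS(=O)(=O)c1cccc(NC(=O)NCCCCl)c1`: > 200000 nM

Compound 1 and compound 2 share one core and differ only by methyl in place of hydrogen on a saturated chain carbon, two bonds along the chain from an aromatic carbon; this change gave a 1.2-fold lower number from compound 1 to compound 2 (0.06 log units; within the scatter). Compound 3 carries a different core; the difference between the core of compound 1 and the core of compound 3 is not broken down here. For compound 3 the value > 200000 nM is a limit of this assay, not a number, as noted under (the limit of > 200000 nM in this assay, at which 1 of the 3 values shown sits).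

Compound 4 `CCCc1ccccc1NS(=O)(=O)c1cccc(NC(=O)NCCCCl)c1` is still to be measured in this assay. It stands to compound 3 as compound 2 stands to compound 1: the change is methyl in place of hydrogen on a saturated chain carbon, two bonds along the chain from an aromatic carbon, the same change at the same place. For compound 4 the expected step is a step that the limit leaves unreadable from compound 3 to compound 4, an expectation resting on the measured step of a 1.2-fold lower number from compound 1 to compound 2 (0.06 log units; within the scatter). Since compound 3 reached only a limit, compound 4 is expected to do the same. Compound 4 is estimated at 250000 nM, with a range from 100000 nM to 700000 nM.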

Compound 4, half-maximal inhibitory concentration: 23000 nM
Beside the measured number, compound 4's estimate is 11-fold (1.04 log units) above it; the whole stated range lies above it.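

In this assay, ethyl to propyl on the core of compound 3 gave an at least 8.6-fold lower number from compound 3 to compound 4 (0.93 log units; beyond the scatter), so the change did not carry over in size from the core of compound 1: the same change on two cores in this assay, a 1.2-fold lower number (0.06 log units; within the scatter) from compound 1 to compound 2 and an at least 8.6-fold lower number (0.93 log units; beyond the scatter) from compound 3 to compound 4, at least 7.5-fold (0.87 log units) apart, beyond the scatter of two such steps.
For compound 3, > 200000 nM is a limit of the assay, not a number.
The step from that core therefore has a lower bound only, and two cores do not show which difference between them goes with the gap, nor how the change would read on any third core.

Open, as far as these compounds go, is whether a longer chain, such as butyl, would continue the trend on either core. Also open, from the compounds shown here alone, is how a carboxylic acid or an amine at the end of that chain would read.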